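A few compounds are considered here, and "the series" means these few. Any claim that something is new, unique, unknown or untested is made for them only; others in the source may bear on it.

Measured so far:
compound 1 `COc1ncc(-c2ccc3nc(NC(=O)NCCN4CCCC4)sc3c2)cc1NS(=O)(=O)c1ccc(F)cc1` — in a functional assay on U-87MG ATCC cells for antiproliferative activity against U-87 MG (Homo sapiens), read by MTT assay, with a stated time of 72 h (on this read-out higher numbers stand for weaker inhibition and lower numbers for stronger inhibition), compound 1 gives 360 nM
compound 2 `CCOC(=O)CNc1nc2ccc(-c3cnc(OC)c(NS(=O)(=O)c4ccc(F)cc4)c3)cc2s1` — in this assay compound 2 gives "not determined" (no result reported)
compound 3 `CCCNc1nc2ccc(-c3cnc(Cl)c(NS(=O)(=O)c4ccc(F)cc4)c3)cc2s1` — in this assay compound 3 gives "not determined" (no result reported)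

Compound 3 stands without a number in this assay; compound 2 is in the same position, so compound 1 holds the only figure in the series. Compound 4 `CCN(CC)CCNC(=O)Nc1nc2ccc(-c3cnc(Cl)c(NS(=O)(=O)c4ccc(F)cc4)c3)cc2s1` is derived from compound 3 by one change: (2-(diethylamino)ethyl)carbamoyl in place of propyl on a nitrogen on an aromatic ring. With no figure for compound 3, no step size in this assay can be measured, and none is assigned. The nearest measured neighbour of compound 4 by structure is compound 1, whose 360 nM is taken as the anchor. Compound 4 is expected to land at 400 nM, within a range of 130 nM to 1200 nM.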

Compound 4, half-maximal inhibitory concentration: 1390 nM
Estimate against measurement, compound 4: 3.5-fold (0.54 log units) below; measured number outside the range, above it.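

In this assay, going by these compounds alone, compound 3 has no figure, so no new step to compound 4 can be read. The compounds shown leave open what the change from propylamino to ((2-(diethylamino)ethyl)carbamoyl)amino does to inhibition. No evidence bears on this result.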